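This account rests on a few compounds, and the source may have more. Where it says the series, first, only, none or still open, it means among the compounds named here.

Measured so far in a functional assay on HEK293 cells for agonist activity at G-protein coupled receptor 39 (Homo sapiens), read by scintillation proximity assay and inositol phosphate accumulation, with a stated time of 75 min; on this read-out lower numbers stand for an effect already at smaller amounts and higher numbers for an effect only at larger amounts of compound:
compound 1 `Cc1cc(C)n(CCOC2CC(=O)Nc3c2c(C)nn3-c2ncnc3nc[nH]c23)n1`: 2000 nM
compound 2 `CCCCCCCCOC1CC(=O)Nc2c1c(C)nn2-c1ncnc2nc[nH]c12`: 388 nM
compound 3 `Cc1nn(-c2ncnc3nc[nH]c23)c2c1C(OCc1ccccc1C#N)CC(=O)N2`: 127 nM

Compound 3 holds the lowest number of the three. Its nearest neighbour is compound 2, seen in the step of a 3.1-fold lower number from compound 2 to compound 3 (0.49 log units; beyond the scatter), and its furthest is compound 1, seen in the step of a 16-fold lower number from compound 1 to compound 3 (1.20 log units; beyond the scatter); the remaining step, a 5.2-fold lower number from compound 1 to compound 2 (0.71 log units; beyond the scatter), links the two higher numbers. All three compounds share the same core and differ only in the group carried through the ether oxygen on the saturated ring carbon.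

Compound 4 `Cc1nn(-c2ncnc3nc[nH]c23)c2c1C(c1ccc(OC(C)C)cc1)CC(=O)N2` breaks with this series: 4-isopropoxyphenyl in place of (2-cyanobenzyl)oxy on a saturated ring carbon. Here the ether oxygen itself is gone, and an aryl ring sits directly on the ring carbon. Among the measured compounds shown here, no measured step covers such a change; the steps from compound 1 and from compound 2 to compound 3 only show that the group at this position moves the read-out of this assay by modest to large amounts. The direction for compound 4 is therefore open, and the expectation rests on the width of the spread seen so far rather than on a matching precedent. Compound 4 is expected near compound 3, with a step of a 2.0-fold higher number from compound 3 to compound 4 (0.29 log units; within the scatter), and its estimated value is 250 nM, within a range from 60 nM to 1000 nM.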

Compound 4, half-maximal effective concentration: 2700 nM
Estimate against measurement, compound 4: 11-fold (1.03 log units) below, and the stated range ends below it.
By their numbers in this assay, from the lowest: compound 3; then compound 2; then compounds 1 and 4 (each within the scatter of the next).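

In this assay, putting 4-isopropoxyphenyl in place of (2-cyanobenzyl)oxy on the saturated ring carbon gives a large step, a 21-fold higher number from compound 3 to compound 4 (1.33 log units; beyond the scatter), although both groups have the same heavy-atom count and one six-membered aromatic ring of carbon only, so neither of these shared features alone sets the read-out at this position. The octyloxy group also stands clearly apart from the aryl group, a 7.0-fold higher number from compound 2 to compound 4 (0.84 log units; beyond the scatter), whereas the group of compound 1, which keeps the ether oxygen and carries a five-membered aromatic ring, shows no separation from it, a 1.4-fold higher number from compound 1 to compound 4 (0.13 log units; within the scatter), so an ether oxygen on this carbon does not by itself bring a lower number. Nothing measured on these compounds gives a reason for these steps.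

Compound 4 both loses the ether oxygen and gains an isopropoxy group, and these two changes cannot be told apart from the compounds shown. Still open, on these data alone, are how a 2-cyanophenyl group bound directly to the ring carbon, a 4-isopropoxybenzyl ether, or an amine or carboxylic acid at the end of the ether chain would read.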